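The source may report more compounds than this note shows. Statements on the series, on what has been measured and on what is new or still open speak of the compounds shown alone.

Measured so far in a functional assay on A2780 cells (Homo sapiens) for antiproliferative activity, read by resazurin assay, with a stated time of 72 h; on this read-out higher numbers stand for weaker inhibition and lower numbers for stronger inhibition:

compound 1, `CN(Cc1cccc(F)c1)C(=O)c1cc2c(Cc3ccccc3)n[nH]c2cc1O`: 5000 nM
compound 2, `CN(Cc1ccc(F)cc1)C(=O)c1cc2c(Cc3ccccc3)n[nH]c2cc1O`: 4100 nM
compound 3, `Cc1cccc(Cc2n[nH]c3cc(O)c(C(=O)N(C)Cc4cccc(F)c4)cc23)c1`: 440 nM

Compounds 1 and 2 share a core and differ only in the fluorinated ring hanging from the amide nitrogen: 4-fluorophenyl in place of 3-fluorophenyl on a saturated chain carbon bound to an amide-type nitrogen. On this assay that swap made a small step, a 1.2-fold lower number from compound 1 to compound 2 (0.09 log units; within the scatter), so the two numbers cannot be told apart. Compound 3 carries the same arm as compound 1 but its core differs in one place: methyl in place of hydrogen on an aromatic carbon. Going by the values given here, that single methyl brought a large step, an 11-fold lower number from compound 1 to compound 3 (1.06 log units; beyond the scatter), and compound 3 also sits well below compound 2, with no direct step counted between those two.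

Compound 4, `Cc1cccc(Cc2n[nH]c3cc(O)c(C(=O)N(C)Cc4ccc(F)cc4)cc23)c1`, is not yet measured. It stands to compound 3 exactly as compound 2 stands to compound 1: 4-fluorophenyl in place of 3-fluorophenyl on a saturated chain carbon bound to an amide-type nitrogen. The place of the change is described in the same words for both pairs, so this is the same change, now on the methyl-bearing core. Among the compounds with values here, the only guide to its effect is the earlier pair, where a 1.2-fold lower number from compound 1 to compound 2 (0.09 log units; within the scatter) stayed within the scatter. On that basis the step from compound 3 to compound 4 is expected to be similarly small, a 1.2-fold lower number from compound 3 to compound 4 (0.08 log units; within the scatter), with the methyl on the core of compound 3 carrying the potency. Compound 4 is therefore estimated at about 370 nM in this assay, with a likely range from 180 nM to 800 nM, close to compound 3 and far below compounds 1 and 2.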

Compound 4, half-maximal inhibitory concentration: 590 nM
Estimate against measurement, compound 4: 1.6-fold (0.20 log units) below; the measured number falls inside the stated range.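

In this assay, the swap of 3-fluorophenyl for 4-fluorophenyl again makes no clear difference on the methyl-bearing core, a 1.3-fold higher number from compound 3 to compound 4 (0.13 log units; within the scatter), and the two cores agree on this: the same change on two cores in this assay, a 1.2-fold lower number (0.09 log units; within the scatter) from compound 1 to compound 2 and a 1.3-fold higher number (0.13 log units; within the scatter) from compound 3 to compound 4, 1.6-fold (0.21 log units) apart, within the scatter of two such steps The methyl change also carries over, since the number still falls on the fluorinated arm of compound 2, a 6.9-fold lower number from compound 2 to compound 4 (0.84 log units; beyond the scatter), and the step lies beyond the scatter on both arms, with the two sizes matching: the same change on two cores in this assay, an 11-fold lower number (1.06 log units; beyond the scatter) from compound 1 to compound 3 and a 6.9-fold lower number (0.84 log units; beyond the scatter) from compound 2 to compound 4, 1.6-fold (0.21 log units) apart, within the scatter of two such steps This shows that, across these four compounds, the two changes behave independently, so the effect of each could be read from one pair and applied to the other, but it rests on a single square of compounds in one assay and does not show that this would hold on other cores or explain why the methyl matters so much.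

The compounds shown leave open whether an ethyl or a chlorine in place of the methyl would give a step of similar size. They also leave open whether a methoxy or a nitrile in place of the fluorine on the arm would make as little difference as moving the fluorine did.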